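Piperidin-1-yl replacing cyclopentyl on the amide carbonyl

The source may hold more compounds than are shown below. What is called first, only, known or untested is meant among the compounds shown, and "the series" means these compounds.

Compound 1, `CC1CC1C(=O)N1CCc2nc(C#Cc3ccccc3)sc2C1`, in an assay on HEK293 cells for positive allosteric modulation of metabotropic glutamate receptor 5 (Homo sapiens), read by FLIPR, with a stated time of 1 h; a lower number here means that less compound is needed, a higher number that more compound is needed for the effect: 9.4 nM
Compound 2, `CC1CC(C(=O)N2CCc3nc(C#Cc4ccccc4)sc3C2)C1`, in this assay: 81 nM
Compound 3, `O=C(C1CCCC1)N1CCc2nc(C#Cc3ccccc3)sc2C1`, in this assay: 19 nM

Among the three measured compounds, compound 3 holds the second highest number: a 2.0-fold higher number from compound 1 to compound 3 (0.31 log units; beyond the scatter), while a 4.3-fold lower number from compound 2 to compound 3 (0.63 log units; beyond the scatter). All three share one core and differ only in the group on the carbonyl carbon, and every measured step there was modest, including an 8.6-fold higher number from compound 1 to compound 2 (0.94 log units; beyond the scatter).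

Compound 4, `O=C(N1CCCCC1)N1CCc2nc(C#Cc3ccccc3)sc2C1`, takes the step (piperidin-1-yl in place of cyclopentyl on a carbonyl carbon). Among the compounds with values here, no measured step involves a nitrogen-linked ring on the carbonyl carbon, so none bears directly on this change; the three measured steps only show that changing the ring on that carbon shifts the number by modest amounts in either direction. Compound 4 is therefore expected to stay in the same modest range, most likely a somewhat higher number than compound 3, with a 2.1-fold higher number from compound 3 to compound 4 (0.32 log units; beyond the scatter) as the estimated step. The estimated value for compound 4 in this assay is 40 nM, with a range from 10 nM to 160 nM.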

Compound 4, half-maximal effective concentration: 75 nM
Compound 4: the middle estimate sits 1.9-fold (0.27 log units) below what was measured; the range from low to high includes it.
By their numbers in this assay, from the lowest: compound 1; then compound 3; then compounds 4 and 2 (each within the scatter of the next).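

In this assay, within the data shown here, piperidin-1-yl is the first group on the carbonyl carbon that is attached through a ring nitrogen, and swapping it for cyclopentyl moves the number by a modest but real amount (a 3.9-fold higher number from compound 3 to compound 4 (0.60 log units; beyond the scatter)). Compound 4 also falls level with compound 2 (a 1.1-fold lower number from compound 2 to compound 4 (0.03 log units; within the scatter)) and remains well off compound 1 (an 8.0-fold higher number from compound 1 to compound 4 (0.90 log units; beyond the scatter)), so among these four compounds the nitrogen-linked ring stays within the span already set by the carbon-linked rings. No measurement shown here accounts for the size of this step.

The compounds shown leave open whether the higher number goes with the nitrogen on the carbonyl carbon or with the six-membered ring. Cyclohexyl on that carbon would test the first of these against compound 4, and pyrrolidin-1-yl would test the second against compound 3.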